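Swapping the Urea Substituent onto the Bicyclic Amide Core

The source may report more compounds than this note shows. Statements on the series, on what has been measured and on what is new or still open speak of the compounds shown alone.

Measured so far:
Compound 1, `COc1ccc(C(=O)NCCC2CCN(S(=O)(=O)NC(=O)NC[C@@H]3C[C@@H]4C=C[C@@H]3C4)CC2)cn1`, gives 11%.
Compound 2, `COc1ccc2nccc(C(=O)NCCC3CCN(S(=O)(=O)NC(=O)NC4CCCCC4)CC3)c2c1`, gives 15%.

Both compounds were tested in a functional assay on the whole organism (blood) with Rattus norvegicus as the target, with stated times of 24 h and 1 h, at a dose of 5 mg/kg by the intraperitoneal route; on this read-out lower numbers stand for a weaker effect and higher numbers for a stronger effect at the one dose given. Compound 2 and compound 1 return numbers that lie within the usual scatter of each other, so on these two results neither can be placed above the other, and compound 2 simply stands among the two at the same level as compound 1.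

Compound 3, `COc1ccc2nccc(C(=O)NCCC3CCN(S(=O)(=O)NC(=O)NC[C@@H]4C[C@@H]5C=C[C@@H]4C5)CC3)c2c1`, has not yet been measured. It keeps the core of compound 2 and carries the change (a group of 8 heavy atoms (8 carbon; 2 five-membered non-aromatic rings of carbon only) in place of a group of 6 heavy atoms (6 carbon; one six-membered non-aromatic ring of carbon only), on an amide-type nitrogen). The group that enters is the same group that already sits on the urea nitrogen of compound 1.

Within the data shown here, no step between measured compounds is known here, so the expectation for compound 3 rests on the two values alone. Because compound 1 gives 11% with that group, and compound 2 gives 15% with the cyclohexyl, a step of a number 2 percentage points lower from compound 2 to compound 3 (within the scatter) is expected, one that stays within the scatter in either direction. Compound 3 is therefore estimated at 13%, with a range from 3% to 25%.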

Compound 3, a percentage reported as activity, at one dose (the size of the read-out at that dose, not a potency): 10%
For compound 3 the middle estimate is 3 percentage points above the measured one; the measured number falls inside the stated range.
By their numbers in this assay, from the lowest: compounds 3, 1 and 2 (each within the scatter of the next).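

In this assay, replacing the cyclohexyl on the amide-type nitrogen with the bridged group of two five-membered rings, which has one double bond and three defined stereocentres, gives a number 5 percentage points lower from compound 2 to compound 3 (within the scatter) and so does not separate the two groups on this core. Compound 1 and compound 2 differ in two places, so their values could not show what either change does alone; with the urea substituent held constant, 6-methoxyquinolin-4-yl in place of 6-methoxypyridin-3-yl on a carbonyl carbon gives a number 1 percentage points lower from compound 1 to compound 3 (within the scatter) and leaves that change equally unresolved in this assay. Neither step therefore shows a clear effect of the change concerned at this one dose, and no measurement here offers an explanation for either result.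

As far as these compounds go, what remains open is whether a different kind of substituent on the urea nitrogen, such as a primary amine, a carboxylic acid or a longer alkyl chain, would move the read-out beyond the usual scatter. From the compounds shown here alone, it is also open whether a simple phenyl on the amide carbonyl would do so, and how these compounds would compare at other doses.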